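The compounds below may be only part of what the source reports. "The series", "measured", "known", "first", "only" and "open" are said of these compounds alone.

Compound 1 `COc1ccc(-c2cc(C(C)=O)c3[nH]c(-c4ccccc4)cc3c2)cc1` gives 49.5% in a functional assay on MCF7 cells (Homo sapiens) for cytotoxicity, read by MTT assay, with a stated time of 2 days, tested at 10 uM; on this read-out lower numbers stand for a stronger effect and higher numbers for a weaker effect at the one concentration tested; compound 2 `CC(=O)c1cc(-c2ccccc2)cc2cc(-c3ccc(F)cc3)[nH]c12` gives 91.9%; compound 3 `CC(=O)c1cc(-c2ccc(F)cc2)cc2cc(-c3ccc(F)cc3)[nH]c12` gives 90.6%.

Compound 3 stands second highest of the three in this assay, within the scatter of compound 2 and far above compound 1. Among the compounds with values here, the single step recorded, a number 1.3 percentage points lower from compound 2 to compound 3 (within the scatter), hardly moved the number. Compound 4 `COc1ccc(-c2cc(C(C)=O)c3[nH]c(-c4ccc(F)cc4)cc3c2)cc1` differs from compound 3 by methoxy in place of fluoro on an aromatic carbon. Within the data shown here, no measured step tests methoxy against fluoro directly; compound 1, which also carries the 4-methoxyphenyl, gives a far lower number than either fluorophenyl compound, though it differs from compound 3 in two places. A fall is therefore expected, a number 35.6 percentage points lower from compound 3 to compound 4 (beyond the scatter), and compound 4 is estimated at 55%, within 35% to 80%.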

Compound 4, a percentage reported as activity, at one concentration (the size of the read-out at that concentration, not a potency): 52.9%
Beside the measured number, compound 4's estimate is 2.1 percentage points above it, within the range that was stated.
By their numbers in this assay, from the lowest: compounds 1 and 4 (each within the scatter of the next); then compounds 3 and 2 (each within the scatter of the next).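

In this assay, the change from 4-fluorophenyl to 4-methoxyphenyl now has a direct measurement, giving a number 37.7 percentage points lower from compound 3 to compound 4 (beyond the scatter), and methoxy in place of hydrogen at the same position gives a number 39 percentage points lower from compound 2 to compound 4 (beyond the scatter). The large fall therefore follows methoxy at this position, whereas fluoro there left the number within the scatter. Fluoro in place of hydrogen at the other site also stays within the scatter with methoxy present, with a number 3.4 percentage points higher from compound 1 to compound 4 (within the scatter), and the two cores agree: the same change on two cores in this assay, a number 1.3 percentage points lower (within the scatter) from compound 2 to compound 3 and a number 3.4 percentage points higher (within the scatter) from compound 1 to compound 4, 4.7 percentage points apart, within the scatter of two such steps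

Only hydrogen, fluoro and methoxy are shown at this position. Going by these compounds, whether a hydroxyl, an ethoxy or an amine there would give a similar fall remains open.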